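The source may report more compounds than this note shows. Statements on the series, on what has been measured and on what is new or still open speak of the compounds shown alone.

Measured in a functional assay on CWR22R cells (Homo sapiens) for inhibition, read by sulforhodamine B assay, with a stated time of 72 h; on this read-out lower numbers stand for stronger inhibition and higher numbers for weaker inhibition:
- compound 1 `COc1ccc(Cn2nnc(O)c2C(=O)Nc2cccc(-c3ccc(O)cc3)c2)cc1`: 67500 nM
- compound 2 `COc1ccc(Cn2nnc(O)c2C(=O)Nc2ccc(Oc3ccccc3)cc2)cc1`: 58200 nM

Compound 1 and compound 2 lie within the scatter of each other, so these two numbers show no separation between them. Compound 3 `COc1ccc(Cn2nnc(O)c2C(=O)Nc2cccc(Oc3ccccc3)c2)cc1` has not yet been measured. It has phenoxy in place of 4-hydroxyphenyl on an aromatic carbon of the ring, meta to a large group (phenoxy in place of 4-hydroxyphenyl on an aromatic carbon). Among the compounds with values here, no measured pair shows this exchange directly, so the expectation rests on thin evidence. Compound 2 also carries phenoxy, at a different place, and compound 2 gives 58200 nM. No change beyond the scatter is therefore expected in this assay, and the estimated step is a 1.2-fold lower number from compound 1 to compound 3 (0.09 log units; within the scatter). For compound 3 the expected value is 55000 nM, with an estimated range of 25000 nM to 100000 nM.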

Compound 3, half-maximal inhibitory concentration: 65000 nM
Beside the measured number, compound 3's estimate is 1.2-fold (0.07 log units) below it, within the range that was stated.
By their numbers in this assay, from the lowest: compounds 2, 3 and 1 (each within the scatter of the next).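

In this assay, within the data shown here, phenoxy in place of 4-hydroxyphenyl on an aromatic carbon, meta to a large group, gives a 1.0-fold lower number from compound 1 to compound 3 (0.02 log units; within the scatter), the first direct reading of this exchange. At this position the two groups are not separated on this read-out, although they have the same count of heavy atoms and differ in that 4-hydroxyphenyl has a hydrogen-bond donor and phenoxy has none. No measurement bears on what lies behind this result.

Going by these compounds, whether a different group at this place, such as an amine or a carboxylic acid, would give a step beyond the scatter remains open. Also open, on these data alone, is whether the same exchange would give a comparable step on a different core.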